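The source may hold more compounds than are shown below. What is called first, only, known or untested is meant among the compounds shown, and "the series" means these compounds.

Measured compounds:
compound 1 `COc1ccc(N2C(=O)C(C)(C)c3cccnc32)cc1` — 42%
compound 2 `CC1(C)C(=O)N(c2cccc(C(F)(F)F)c2)c2ncccc21` — 10%

In a functional assay on the whole organism (Pleural cavity) for inhibition, with Rattus norvegicus as the target, at a dose of 25 mg/kg (on this read-out higher numbers stand for more inhibition at the one dose given (going by the name of the read-out) and lower numbers for less inhibition), compound 1 gives 42%, the higher of the two numbers recorded. Compound 2 gives 10%, a gap beyond the usual scatter, though the two structures differ in more than one place, so nothing is known of any single change behind that gap. Compound 3 `CC(C)c1ccc(N2C(=O)C(C)(C)c3cccnc32)cc1` carries isopropyl in place of methoxy on an aromatic carbon. Within the data shown here, no measured pair shows this change, so the size of the step can only be expected: a modest fall, possibly no more than the scatter. Compound 3 is estimated at 32%, between 12% and 50%, an expected step of a number 10 percentage points lower from compound 1 to compound 3 (within the scatter).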

Compound 3, a percentage reported as inhibition, in the whole organism at one dose (the size of the read-out at that dose, not a potency): 6%
For compound 3 the middle estimate is 26 percentage points above the measured one; the measured number lies below the stated range.
By their numbers in this assay, from the lowest: compounds 3 and 2 (each within the scatter of the next); then compound 1.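

In this assay, isopropyl in place of methoxy on an aromatic carbon, para to a large group, gives a large change: a number 36 percentage points lower from compound 1 to compound 3 (beyond the scatter). Among these compounds, with the core unchanged, this is the first reading of one group swapped alone, and it shows that the result depends on which of these two groups sits at this position. Nothing available explains the step.

Still open, on these data alone, is whether an ethoxy group, with its oxygen and a longer chain, would hold the level of compound 1. An amine or a hydroxyl group at this carbon could also tell whether methoxy is unusual here.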